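This account rests on a few compounds, and the source may have more. Where it says the series, first, only, none or still open, it means among the compounds named here.

Compound 1 `CCOc1ccccc1N1C(=O)C(C)SC1c1cccc(C(=O)NCCCCc2ccccc2)c1`: 85%
Compound 2 `CCN1C(=O)CSC1c1cccc(C(=O)NCCCCc2ccccc2)c1`: 3%

In a functional assay on SJSA-1 cells (Homo sapiens) for inhibition, read by CCK-8 assay, with a stated time of 72 h, tested at 1 uM (on this read-out higher numbers stand for more inhibition at the one concentration tested (going by the name of the read-out) and lower numbers for less inhibition), compound 2 gives 3%, the lower of the two numbers, while compound 1 gives 85%, a gap beyond the usual scatter. Compound 3 `O=C(NCCCCc1ccccc1)c1cccc(C2SCC(=O)N2c2ccccc2F)c1` has not yet been measured; it differs from compound 2 by 2-fluorophenyl in place of ethyl on an amide-type nitrogen in a ring. Although it differs from compound 2 in other places as well, compound 1 also carries an aromatic ring on that nitrogen, and compound 1 gives 85%, so an upward step beyond the scatter is expected in this assay: the expected step is a number 57 percentage points higher from compound 2 to compound 3 (beyond the scatter). Compound 3 is estimated at 60%, within a range from 25% to 88%.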

Compound 3, a percentage reported as inhibition, at one concentration (the size of the read-out at that concentration, not a potency): 80%
Estimate against measurement, compound 3: 20 percentage points below; measured number inside the range.
By their numbers in this assay, from the lowest: compound 2; then compounds 3 and 1 (each within the scatter of the next).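

Putting 2-fluorophenyl in place of ethyl on the amide-type nitrogen in the ring gives a number 77 percentage points higher from compound 2 to compound 3 (beyond the scatter) in this assay with nothing else in the molecule changed. Compound 1 hinted at this, but it differs from compound 2 in other places as well; this single-place pair ties the large rise to this nitrogen substituent alone. Nothing shown accounts for the size of the step. As far as these compounds go, whether the aromatic ring or its fluorine matters more remains open. Plain phenyl or benzyl on that nitrogen would help separate the two.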